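The source may report more compounds than this note shows. Statements on the series, on what has been measured and on what is new or still open speak of the compounds shown alone.

Measured compounds:
Compound 1, `C=C1CC(COc2cc(C(=O)O)n(C)n2)(c2ccc(Cl)cc2)OC1=O`, in a functional assay on K562 cells (Homo sapiens) for antiproliferative activity; on this read-out higher numbers stand for weaker inhibition and lower numbers for stronger inhibition: > 10000 nM.
Compound 2, `C=C1CC(C)(COc2cc(C(=O)O)n(C)n2)OC1=O`, in this assay: > 10000 nM.

The value for compound 1 in this assay is a limit of the assay, not a number. The value for compound 2 in this assay is likewise a limit. For the measured compounds named here, the only measured step, methyl in place of 4-chlorophenyl on a saturated ring carbon, reads a step that the two limits leave unreadable from compound 1 to compound 2, so its size cannot be taken from these two values. What the two measurements share is the limit of > 10000 nM in this assay, at which 2 of the 2 values shown sit.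

Compound 3, `C=C1CC(COc2cc(C(=O)O)n(C)n2)(c2ccc(-c3ccccc3)cc2)OC1=O`, differs from compound 1 by phenyl in place of chloro on an aromatic carbon. Going by the values given here, no measured step touches this position, and the one step that is measured gives no readable size, so there is no ground to expect a step beyond the scatter in either direction. Compound 3 is therefore expected to sit where compound 1 sits, at the limit, with an expected step that the limit leaves unreadable from compound 1 to compound 3. The estimate for compound 3 in this assay is 15000 nM, within 5000 nM to 50000 nM.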

Compound 3, half-maximal inhibitory concentration: > 10000 nM
Compound 3 gave a limit, no number; the forecaster's own chance of this, stated with the estimate: 80%; the middle value lies beyond the limit too.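

No size can be read for the change from compound 1 to compound 3, phenyl in place of chloro on an aromatic carbon, as both values are limits and not numbers; all the compounds shown sit at one value: the limit of > 10000 nM in this assay, at which 3 of the 3 values shown sit. Going by these compounds, how far any of them lies beyond that limit in this assay stays open, as does which change to the shared core would give a measurable value.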